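Moving the bromine on the anilino ring of a weak cytotoxic series

The source may hold more compounds than are shown below. What is called first, only, known or untested is meant among the compounds shown, and "the series" means these compounds.

Compound 1 `Fc1cccc(-c2nc(Nc3ccc(Cl)cc3)c3cc(F)ccc3n2)c1` was tested in a functional assay on U2OS cells (Homo sapiens) for cytotoxicity, read by MTT assay, with a stated time of 48 h (on this read-out lower numbers stand for stronger inhibition and higher numbers for weaker inhibition), and gave 38400 nM. Compound 2 `Fc1cccc(-c2nc(Nc3cccc(Br)c3)c3cc(F)ccc3n2)c1` gives in this assay only a limit, > 50000 nM. The step of an at least 1.3-fold higher number from compound 1 to compound 2 (0.11 log units; that floor lies within the scatter) therefore rests on a value sitting at the limit of > 50000 nM in this assay, at which 1 of the 2 values shown sits. Compound 3 `Fc1cccc(-c2nc(Nc3ccccc3Br)c3cc(F)ccc3n2)c1` differs from compound 2 by 2-bromophenyl in place of 3-bromophenyl on a nitrogen on an aromatic ring. For the measured compounds named here, only that one measured step bears on this change, and it stays within the scatter, so no shift beyond the scatter is expected for a number no higher from compound 2 to compound 3 (the limit leaves the size open). Compound 3 is accordingly estimated at 50000 nM, within 20000 nM to 120000 nM.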

Compound 3, half-maximal inhibitory concentration: > 50000 nM
Compound 3 gave a limit, no number (the forecaster's own chance of this, stated with the estimate: 60%); the middle value sits exactly at the limit.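

Placing the bromine as 2-bromophenyl rather than 3-bromophenyl yields no readable number in this assay, so the step between compound 2 and compound 3 cannot be read. For the compounds shown here, the only readable comparison is an at least 1.3-fold higher number from compound 1 to compound 3 (0.11 log units; that floor lies within the scatter), which does not set the 2-bromophenyl group apart from the 4-chlorophenyl group. Limits now account for most of this small set: the limit of > 50000 nM in this assay, at which 2 of the 3 values shown sit.

On these data alone, whether an amine or a carboxylic acid in place of the bromine would give a readable number in this assay stays open. So does the real size of any difference between compound 2 and compound 3.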